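A few compounds are considered here, and "the series" means these few. Any claim that something is new, unique, unknown or untested is made for them only; others in the source may bear on it.

Compound 3 `Cc1c(OCCCCOc2ccc(C(=O)O)cc2)ccc(C(=O)CC(C)C)c1O` is one of three close relatives built on a shared core. Among the compounds with values here, in an assay on HEK293 cells for positive allosteric modulation of metabotropic glutamate receptor 2 (Rattus norvegicus), read by thallium flux, with a stated time of 2.5 min (a higher number here means that more compound is needed for the effect, a lower number that less compound is needed), compound 3 gives 122 nM, the lower of the two numbers known so far; compound 1 `Cc1c(OCCCCOc2ccc(C(=O)O)cc2)ccc(C(=O)CC2CCCC2)c1O` gives 824 nM, and for compound 2 `Cc1c(OCCCCOc2ccc(C(=O)O)cc2)ccc(C(=O)CC(C)C)c1C` the result is "not determined" (no result reported). Within the data shown here, the only measured step, a 6.8-fold lower number from compound 1 to compound 3 (0.83 log units; beyond the scatter), concerns a different group, the chain on the saturated carbon bound to a carbonyl carbon. Compound 4 `Cc1cc(OCCCCOc2ccc(C(=O)CC(C)C)c(O)c2C)ccc1C(=O)O` differs from compound 3 by methyl in place of hydrogen on an aromatic carbon. Among the measured compounds shown here, no measured step touches this part of the molecule, so the one known step gives no guide, and nothing beyond the scatter is expected in this assay. The estimate for compound 4 is therefore 150 nM, with a range from 50 nM to 450 nM, which means an expected step of a 1.2-fold higher number from compound 3 to compound 4 (0.09 log units; within the scatter).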

Compound 4, half-maximal effective concentration: 173 nM
Beside the measured number, compound 4's estimate is 1.2-fold (0.06 log units) below it; the measured number falls inside the stated range.
By their numbers in this assay, from the lowest: compounds 3 and 4 (each within the scatter of the next); then compound 1.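

Placing a methyl on the aromatic carbon ortho to the carboxy group, which turns 4-carboxyphenyl into 4-carboxy-3-methylphenyl, gives a 1.4-fold higher number from compound 3 to compound 4 (0.15 log units; within the scatter) in this assay. Within the data shown here, this is the first sign that this position can carry one added carbon with no change that stands out from the scatter, though a single pair cannot show a general rule. Nothing available accounts for this result. As far as these compounds go, whether an ethyl group, a methoxy group or a chlorine atom at this carbon would be tolerated as well remains open, as does the effect of the same methyl with the cyclopentyl chain of compound 1.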